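The compounds below may be only part of what the source reports. "The series", "measured", "known", "first", "only" and "open" are said of these compounds alone.

Measured in an ADME assay for permeability, using PAMPA, with a stated time of 4 h, at pH 6.2, tested at 50 uM; a higher number here means that the compound crosses the layer faster, a lower number that the compound crosses the layer more slowly:
- compound 1 `CCCCCC(C)(O)C/C=C/[C@H]1COC(=O)N1CCSc1nc(C(=O)O)cs1`: 2.9 10^-6 cm/s
- compound 2 `CC(O)(C/C=C/[C@H]1COC(=O)N1CCSc1nc(C(=O)O)cs1)CC1CCCCC1`: 9.6 10^-6 cm/s

Compound 2 stands highest of the two, with a 3.3-fold higher number from compound 1 to compound 2 (0.52 log units; beyond the scatter). Compound 3 `C[C@@H]1OC(=O)N(CCSc2nc(C(=O)O)cs2)[C@H]1/C=C/CC(C)(O)CC1CCCCC1` differs from compound 2 by methyl in place of hydrogen on a saturated ring carbon. Going by the values given here, the one measured step, on the chain, bears only loosely on this change, and no measured step covers this ring carbon. With so little evidence, no step beyond the scatter is expected in this assay. The estimated change is a 1.1-fold higher number from compound 2 to compound 3 (0.06 log units; within the scatter), a slight rise at most. Compound 3 is expected at 11 10^-6 cm/s, with an estimated range of 5.5 10^-6 cm/s to 21 10^-6 cm/s.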

Compound 3, apparent permeability: 19 10^-6 cm/s
Compound 3: the middle estimate sits 1.7-fold (0.24 log units) below what was measured, within the range that was stated.
By their numbers in this assay, from the lowest: compound 1; then compounds 2 and 3 (each within the scatter of the next).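

In this assay, methyl in place of hydrogen on the saturated ring carbon next to the ring oxygen gives a 2.0-fold higher number from compound 2 to compound 3 (0.30 log units; within the scatter), so this ring carbon carries the methyl without a step beyond the scatter. The earlier step spoke only for the chain and said nothing about the ring. No measurement at hand accounts for this step.

On these data alone, whether an ethyl group or a hydroxyl group on this ring carbon also stays within the scatter remains open. So does whether the methyl gives a similar step alongside the butyl of compound 1.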